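Adding a trifluoromethyl group to a fluorinated chalcone-like scaffold

The source may hold more compounds than are shown below. What is called first, only, known or untested is meant among the compounds shown, and "the series" means these compounds.

Of the compounds shown here, two built on the same core have been measured in a functional assay on LNCaP C4-2B cells (Homo sapiens) for cytotoxicity, read by MTT assay, with a stated time of 72 h; a higher number here means a weaker inhibitor, a lower number a stronger inhibitor. Compound 1, `CC1=CCCC(C)(C)C1/C=C/C(=O)/C=C/c1cccc(C(F)(F)F)c1`, carries a trifluoromethyl group on its aromatic ring, and in this assay compound 1 gives 4400 nM. Compound 2, `CC1=CCCC(C)(C)C1/C=C/C(=O)/C=C/c1ccccc1F`, carries a fluoro group instead, and in this assay compound 2 gives 6000 nM. These two numbers lie within the usual scatter of each other, so neither compound can be called the stronger or the weaker of the pair.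

Compound 3, `CC1=CCCC(C)(C)C1/C=C/C(=O)/C=C/c1cc(C(F)(F)F)ccc1F`, combines both features. Relative to compound 2 the change is trifluoromethyl in place of hydrogen on an aromatic carbon. Because compound 1 gives 4400 nM with a trifluoromethyl group present on its own, this addition is not expected to move the number much. The step from compound 2 to compound 3 is therefore expected to be a 1.3-fold lower number from compound 2 to compound 3 (0.12 log units; within the scatter), which is no change beyond the scatter. On that basis compound 3 is estimated to give 4500 nM in this assay, within a range from 1800 nM to 11000 nM.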

Compound 3, half-maximal inhibitory concentration: 4700 nM
Compound 3: middle estimate off by 1.0-fold (0.02 log units), on the low side; the range from low to high includes it.
By their numbers in this assay, from the lowest: compounds 1, 3 and 2 (each within the scatter of the next).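

Within this assay, trifluoromethyl in place of hydrogen on an aromatic carbon, para to a fluoro group, gives a 1.3-fold lower number from compound 2 to compound 3 (0.11 log units; within the scatter), and fluoro in place of hydrogen on an aromatic carbon gives a 1.1-fold higher number from compound 1 to compound 3 (0.03 log units; within the scatter). The earlier compounds shown here showed each of these two groups only on its own, whereas compound 3 carries both on one ring, so each group can now be read as a single step, and neither step lies beyond the scatter. No independent measurement is available here to explain this result.

All three compounds carry only fluorine-containing groups on the aromatic ring, so these results say nothing about groups of another kind. Whether an amine or a carboxylic acid on this same aromatic carbon, para to a fluoro group, would give a step beyond the scatter remains an open question, as does the result for a longer chain such as an ethyl or propyl group there.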